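Cytotoxicity notes: from compound 3 to compound 4

The compounds below may be only part of what the source reports. "The series", "measured", "known", "first", "only" and "open" are said of these compounds alone.

For the measured compounds named here, in an ADME assay on L02 cells (Homo sapiens) for cytotoxicity, read by MTT assay, with a stated time of 24 h (on this read-out lower numbers stand for higher toxicity in this test and higher numbers for lower toxicity in this test), compound 3 `Cc1cccc(-n2cc(-c3ccc(NS(=O)(=O)c4c[nH]c(=O)[nH]c4=O)cc3)nn2)c1` gives 39000 nM, the only plain number in this set. Compound 1 `O=c1[nH]cc(S(=O)(=O)Nc2ccccc2-c2cn(-c3ccccc3F)nn2)c(=O)[nH]1` is reported in this assay only as a limit, > 100000 nM (the limit of > 100000 nM in this assay, at which 1 of the 3 values shown sits). Compound 2 `O=c1[nH]cc(S(=O)(=O)Nc2ccccc2-c2cn(-c3cccc(F)c3)nn2)c(=O)[nH]1` is recorded in this assay as "not toxic" (no number reported), without a number. Compound 3 therefore stands as the single numerical reference point; the other two entries cannot be ranked against it.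

Compound 4 `O=c1[nH]cc(S(=O)(=O)Nc2ccc(-c3cn(-c4ccc(F)cc4)nn3)cc2)c(=O)[nH]1` has not yet been measured. It differs from compound 3 by 4-fluorophenyl in place of 3-methylphenyl on an aromatic nitrogen, with the shared core otherwise unchanged. Going by the values given here, no pair of measured compounds isolates this change, so its effect in this assay has no precedent within the set. Exchanging 3-methylphenyl for 4-fluorophenyl on the aromatic nitrogen is expected to shift this assay by no more than the usual scatter, in no preferred direction. Compound 4 is accordingly expected to give 50000 nM, within a range of 15000 nM to 150000 nM. That change is estimated at a 1.3-fold higher number from compound 3 to compound 4 (0.11 log units; within the scatter), essentially flat, with a real chance that only a limit is reported.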

Compound 4, half-maximal cytotoxic concentration: "not toxic" (no number reported)
No number was reported for compound 4, and the estimate cannot be compared.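

In this assay, for the compounds shown here, compound 4 carries no number, so no step from compound 3 to compound 4 can be read. Compound 1 remains a limit: the limit of > 100000 nM in this assay, at which 1 of the 4 values shown sits. The compounds shown leave open whether exchanging 3-methylphenyl for 4-fluorophenyl on the aromatic nitrogen changes this read-out at all.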